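Swapping the Bromophenyl Arm for a Dichlorophenyl One

The source may report more compounds than this note shows. Statements on the series, on what has been measured and on what is new or still open speak of the compounds shown alone.

Compound 1 `CC(C)c1ccc(NCC(=O)N[C@H]2CCOC2=O)cc1` in a functional assay on DU-145 cells (Homo sapiens) for antiproliferative activity, read by MTT assay, with a stated time of 72 h (a higher number here means a weaker inhibitor, a lower number a stronger inhibitor), gives > 64000 nM, which is a limit of the assay and not a number.
Compound 2 `O=C(CNc1ccc(Cl)cc1Cl)N[C@H]1CCOC1=O` in this assay gives > 64000 nM, again only a limit of the assay.
Compound 3 `O=C(COc1ccc(C(=O)/C=C/c2ccc(Br)cc2)cc1)N[C@H]1CCOC1=O` in this assay gives 51700 nM.

Compound 3 therefore stands as the only one of the three with a measured number. Compounds 1 and 2 both sit at a limit, as the limit of > 64000 nM in this assay, at which 2 of the 3 values shown sit, shows. Compound 4 `O=C(COc1ccc(C(=O)/C=C/c2ccc(Cl)cc2Cl)cc1)N[C@H]1CCOC1=O` keeps everything in compound 3 except one change: 2,4-dichlorophenyl in place of 4-bromophenyl on a double-bonded chain carbon bound to a double-bonded chain carbon. For the measured compounds named here, no two measured compounds differ in a single place, so there is no measured step to lean on. The expected step from compound 3 to compound 4 is a 1.1-fold lower number from compound 3 to compound 4 (0.06 log units; within the scatter), a change not beyond the usual scatter, because compound 3 already gives 51700 nM with a bromine-bearing phenyl in the same place. Compound 4 is thus estimated at about 45000 nM, expected to fall between 15000 nM and 130000 nM, with a real chance that only a limit is reported.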

Compound 4, half-maximal inhibitory concentration: 8610 nM
Estimate against measurement, compound 4: 5.2-fold (0.72 log units) above; the measured number lies below the stated range.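

Putting 2,4-dichlorophenyl in place of 4-bromophenyl gives a 6.0-fold lower number from compound 3 to compound 4 (0.78 log units; beyond the scatter) in this assay. For the compounds shown here, this is the first measured step in the set, and it shows that the number responds to the phenyl group on a double-bonded chain carbon bound to a double-bonded chain carbon, while the rest of the molecule stays the same. The step reads the swap only as a whole, since the kind of halogen and the count of halogens change together.

A phenyl carrying a single chlorine, or one carrying two bromines, would separate those two changes, and an amine on that phenyl would test a group of a different kind. Compounds 1 and 2 differ from compounds 3 and 4 in more than one place and add no number to compare: the limit of > 64000 nM in this assay, at which 2 of the 4 values shown sit.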